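Swapping a Chlorophenyl for a Pyridine Ring

This account rests on a few compounds, and the source may have more. Where it says the series, first, only, none or still open, it means among the compounds named here.

Of the compounds shown here, three sharing one core have been measured in an assay on LtK cells with ATP-sensitive inward rectifier potassium channel 11 (Homo sapiens) as the target; a lower number here means that less compound is needed, a higher number that more compound is needed for the effect. Compound 1 `O=C(Nc1c(C(O)(C(F)(F)F)C(F)(F)F)ccc2ccccc12)C1CCC1` gives 45 nM. Compound 3 `Cc1ccc(C(=O)Nc2c(C(O)(C(F)(F)F)C(F)(F)F)ccc3ccccc23)cc1` gives 76 nM. Compound 2 `O=C(Nc1c(C(O)(C(F)(F)F)C(F)(F)F)ccc2ccccc12)c1cccc(Cl)c1` gives 98 nM, the highest of the three numbers. Going between the measured pairs, there is a 2.2-fold higher number from compound 1 to compound 2 (0.34 log units; beyond the scatter), whereas a 1.3-fold lower number from compound 2 to compound 3 (0.11 log units; within the scatter) lies within the scatter. Compound 4 `O=C(Nc1c(C(O)(C(F)(F)F)C(F)(F)F)ccc2ccccc12)c1cccnc1` is not yet measured and differs from compound 2 in one place: pyridin-3-yl in place of 3-chlorophenyl on a carbonyl carbon. Among the measured compounds shown here, the only comparable exchange of one aromatic ring for another on the carbonyl carbon, from compound 2 to compound 3, stayed within the scatter, so in this assay a step of a 1.2-fold higher number from compound 2 to compound 4 (0.09 log units; within the scatter) is expected, one not beyond the scatter. The estimate for compound 4 is 120 nM, with a range from 50 nM to 300 nM.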

Compound 4, half-maximal effective concentration: 60 nM
Compound 4: middle estimate off by 2.0-fold (0.30 log units), on the high side; low and high end bracket the measured number.
By their numbers in this assay, from the lowest: compounds 1, 4, 3 and 2 (each within the scatter of the next, the first and the last beyond it).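

In this assay a ring with a hetero atom and one hydrogen-bond acceptor is accepted on this carbonyl carbon, with a 1.6-fold lower number from compound 2 to compound 4 (0.21 log units; within the scatter) showing that pyridin-3-yl and 3-chlorophenyl are not told apart here. The other two steps also stay within the scatter, namely a 1.3-fold lower number from compound 3 to compound 4 (0.10 log units; within the scatter) and a 1.3-fold higher number from compound 1 to compound 4 (0.12 log units; within the scatter), so compound 4 falls within the scatter of all three earlier compounds. Nothing available here bears on why these steps are small. As far as these compounds go, what an amine or a carboxylic acid on the pyridin-3-yl ring would do remains open, and so does the effect of a longer chain on the carbonyl carbon.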